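A Chloro Group Added to a Shared Core

The source may report more compounds than this note shows. Statements on the series, on what has been measured and on what is new or still open speak of the compounds shown alone.

Measured compounds:
compound 1, `COc1ccc(-n2sc(=O)n(-c3ccccc3)c2=O)cc1`: in an ADME assay, in phosphate buffer, with a stated time of 30 min, tested at 1 mM, at a dose of 1 mM (a higher number here means more compound in the circulation at the dose given, a lower number less compound in the circulation), compound 1 gives < 2000 nM, which is a limit of the assay and not a number.
compound 2, `O=c1sn(-c2ccccc2)c(=O)n1-c1ccccc1`: in this assay compound 2 gives < 2000 nM, likewise a limit of the assay.

Compound 1 therefore stands only at a limit in this assay, with no number of its own, and the second value shown is a limit as well. For the measured compounds named here, the one measured step, a step that the two limits leave unreadable from compound 1 to compound 2, replaces hydrogen in place of methoxy on an aromatic carbon; its size cannot be read since both ends sit at the limit of < 2000 nM in this assay, at which 2 of the 2 values shown sit.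

Compound 3 is `COc1ccc(-n2sc(=O)n(-c3ccc(Cl)cc3)c2=O)cc1`. It differs from compound 1 by chloro in place of hydrogen on an aromatic carbon. Going by the values given here, no measured step involves a chloro group, so nothing among the measured compounds bears directly on this change, and the one step that was measured is itself unreadable. The step that the limit leaves unreadable from compound 1 to compound 3 is therefore estimated as none beyond the scatter. Compound 3 is expected to give about 900 nM in this assay, somewhere between 250 nM and 3000 nM, and most likely to be reported again only as a limit.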

Compound 3, maximal plasma concentration: < 2000 nM
Compound 3 was reported as a limit; the forecaster's own chance of this, stated with the estimate: 75%; the middle value is on the limit's open side.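

Compound 3, like compound 1, is reported in this assay only as a limit of the assay and not as a number, so no size can be read for the step between them: the limit of < 2000 nM in this assay, at which 3 of the 3 values shown sit. The compounds shown leave open how far each one's maximal plasma concentration lies from that limit, and whether chloro in place of hydrogen changes it at all.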